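Halogen swap on the anilino ring: outlook for compound 3

The compounds below may be only part of what the source reports. "The series", "measured", "known", "first", "only" and "open" are said of these compounds alone.

Measured so far:
compound 1, `CN1CCN(CCCOc2cccc3nc(Nc4ccc(Cl)c(F)c4)ccc23)CC1`: 9120 nM
compound 2, `CN1CCN(CCCOc2cccc3nc(Nc4ccc(F)c(F)c4)ccc23)CC1`: 16200 nM

Both numbers come from a functional assay on cells (Panel NCI-60 (60 carcinoma cell lines), Homo sapiens) for inhibition, read by sulforhodamine B assay, with a stated time of 48 h; on this read-out higher numbers stand for lower toxicity in this test and lower numbers for higher toxicity in this test. Among the compounds with values here, compound 2 and compound 1 are the only two measured members, and the single step between them, a 1.8-fold higher number from compound 1 to compound 2 (0.25 log units; within the scatter), leaves compound 2 not set apart from compound 1; the two numbers are effectively one level.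

The next compound, compound 3, `CN1CCN(CCCOc2cccc3nc(Nc4cc(Cl)cc(Cl)c4)ccc23)CC1`, differs from compound 2 only on the anilino side: 3,5-dichlorophenyl in place of 3,4-difluorophenyl on a nitrogen on an aromatic ring. Within the data shown here, the only measured step that bears on this change is a 1.8-fold higher number from compound 1 to compound 2 (0.25 log units; within the scatter), which exchanged one halogen for another on the same ring and stayed within the scatter. Among the measured compounds shown here, no measured step addresses moving a halogen to a different position on that ring, and none addresses two chlorines together, so the expectation rests on the one halogen swap seen. On that basis no step beyond the scatter is expected in this assay for compound 3, and the expected step from compound 2 is a 1.4-fold lower number from compound 2 to compound 3 (0.13 log units; within the scatter). Compound 3 is therefore estimated at 12000 nM, with a range from 4000 nM to 36000 nM.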

Compound 3, concentration lethal to 50% of the cells: 8320 nM
For compound 3 the middle estimate is 1.4-fold (0.16 log units) above the measured one, within the range that was stated.
By their numbers in this assay, from the lowest: compounds 3, 1 and 2 (each within the scatter of the next).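

In this assay, the change at this position now goes beyond exchanging one halogen: 3,5-dichlorophenyl in place of 3,4-difluorophenyl on a nitrogen on an aromatic ring gives one step (a 1.9-fold lower number from compound 2 to compound 3 (0.29 log units; within the scatter)), and the same group in place of 4-chloro-3-fluorophenyl gives another (a 1.1-fold lower number from compound 1 to compound 3 (0.04 log units; within the scatter)). Both steps alter the halogen pattern on that ring, not just one halogen, and both stay within the scatter, so compound 1, compound 2 and compound 3 remain effectively one level, with no separation between the three anilino groups. Nothing at hand explains this flat picture.

Since both steps change halogen identity and placement together, the contribution of each remains unresolved, and a single-halogen phenyl would be needed to separate them. Going by these compounds, whether this level persists without halogens is also open, for example with an unsubstituted phenyl, a methoxy group or a nitrile on the ring, and so is whether the number moves at all when a carboxylic acid or a longer chain appears on that ring.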